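A Methyl on an Aromatic Oxygen: Hydroxy to Methoxy

This account rests on a few compounds, and the source may have more. Where it says the series, first, only, none or still open, it means among the compounds named here.

Measured compounds:
compound 1, `CC(O)(C(=O)Nc1ccc(S(=O)(=O)c2ccccc2O)cc1)C(F)(F)F`: 3090 nM
compound 2, `COc1ccccc1S(=O)(=O)c1ccc(NC(=O)C(C)(O)C(F)(F)F)cc1`: 1600 nM
compound 3, `CC(O)(C(=O)Nc1ccc(C(=O)c2ccccc2)cc1O)C(F)(F)F`: 15000 nM

All three were tested in a functional assay (Cavia porcellus) with sulfonylurea receptors; K-ATP channels (Homo sapiens) as the target; on this read-out lower numbers stand for stronger inhibition and higher numbers for weaker inhibition. Compound 1 and compound 2 share one core, and compound 3 carries a different core; the difference between the two cores is not broken down here. Compound 3 gives the highest number of the three, with 15000 nM, well apart from the other two.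

Within the first core, the change methyl in place of hydrogen on an oxygen on an aromatic ring was measured directly and gave a 1.9-fold lower number from compound 1 to compound 2 (0.29 log units; within the scatter), so it left the read-out essentially where it was.

Compound 4, `COc1cc(C(=O)c2ccccc2)ccc1NC(=O)C(C)(O)C(F)(F)F`, has not yet been measured in this assay. It arises from compound 3 by methyl in place of hydrogen on an oxygen on an aromatic ring. The place of the change is described in the same words for both pairs, so this is the same change carried over to the second core, although cut one bond further out the earlier pair also reads 2-hydroxyphenyl to 2-methoxyphenyl, which is not said of the later pair.

Among the measured compounds shown here, only one measured example of this change exists, and it did not move the number beyond the usual scatter. For the measured compounds named here, the step from compound 3 to compound 4 is therefore expected to be small as well, about a 1.5-fold lower number from compound 3 to compound 4 (0.18 log units; within the scatter), resting on the single example a 1.9-fold lower number from compound 1 to compound 2 (0.29 log units; within the scatter). Compound 4 is thus estimated at 10000 nM, with a likely range from 4000 nM to 25000 nM.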

Compound 4, half-maximal inhibitory concentration: 6100 nM
Estimate against measurement, compound 4: 1.6-fold (0.21 log units) above, and the stated range covers the measured number.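

Replacing hydroxy with methoxy on the second core gives a 2.5-fold lower number from compound 3 to compound 4 (0.39 log units; beyond the scatter) in this assay, a modest step that lies just beyond the usual scatter. Set beside the earlier result, the change lowers the number on both cores, and the two steps cannot be told apart in size: the same change on two cores in this assay, a 1.9-fold lower number (0.29 log units; within the scatter) from compound 1 to compound 2 and a 2.5-fold lower number (0.39 log units; beyond the scatter) from compound 3 to compound 4, 1.3-fold (0.10 log units) apart, within the scatter of two such steps. So one step lying within the scatter and the other beyond it is no real difference between the cores, and the change carried over between these two, but two pairs cannot show that it would do so on other cores, nor do they explain why the number falls.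

On these data alone, both pairs place only a methyl on the oxygen, so it remains open whether a longer chain such as ethyl would continue the trend, or whether an amine in place of the hydroxy would give a similar step. All four compounds also carry the trifluoromethyl group, which leaves open whether the change would behave the same way on compounds with a plain methyl or another group there instead.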